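The source may report more compounds than this note shows. Statements on the series, on what has been measured and on what is new or still open speak of the compounds shown alone.

Three compounds share one core. Compound 1 `c1ccc(-c2cccc3c2CCC3c2ncc[nH]2)nc1` carries a pyridin-2-yl group on an aromatic carbon, compound 2 `c1cc(-c2ccn[nH]2)c2c(c1)C(c1ncc[nH]1)CC2` a 1H-pyrazol-5-yl group in the same place, and compound 3 `Cn1ccc(-c2cccc3c2CCC3c2ncc[nH]2)n1` a 1-methyl-1H-pyrazol-3-yl group. In a functional assay on CHO cells for agonist activity at Alpha-1A adrenergic receptor (Homo sapiens), read by FLIPR and calcium flux (on this read-out higher numbers stand for larger maximal responses and lower numbers for smaller maximal responses), compound 1 gives 53%, compound 2 gives 83%, and compound 3 gives 19%, the lowest of the three numbers. The two steps that arrive at compound 3 are both downward and both beyond the scatter: a number 34 percentage points lower from compound 1 to compound 3 (beyond the scatter) and a number 64 percentage points lower from compound 2 to compound 3 (beyond the scatter). The step from compound 1 to compound 2 goes the other way, a number 30 percentage points higher from compound 1 to compound 2 (beyond the scatter).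

Compound 4 `COc1cccc2c1CCC2c1ncc[nH]1` is the next step from compound 3: methoxy in place of 1-methyl-1H-pyrazol-3-yl on an aromatic carbon. For the measured compounds named here, none of the measured steps exchanges a ring for a chain at this carbon, so no step bears directly on this change; the measured steps only show that swapping one group at this position for another has moved the maximal response by large amounts in either direction. The expectation for compound 4 therefore leans on the fact that compound 3 sits lowest, so a change away from it is estimated more likely to raise than to lower the number, though by an uncertain amount. For compound 4 a value of 40% is expected in this assay, within a range from 10% to 75%. That estimate amounts to an expected step of a number 21 percentage points higher from compound 3 to compound 4 (beyond the scatter).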

Compound 4, largest response reached (Emax), in percent of the reference or control that the assay uses: 65%
Estimate against measurement, compound 4: 25 percentage points below; the measured number falls inside the stated range.
By their numbers in this assay, from the lowest: compound 3; then compound 1; then compound 4; then compound 2.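

The result shows that a ring is not needed on this aromatic carbon for a substantial maximal response: in this assay, replacing the 1-methyl-1H-pyrazol-3-yl group with methoxy, which has no ring and fewer heavy atoms, gives a number 46 percentage points higher from compound 3 to compound 4 (beyond the scatter). Methoxy also fits within the order set by the ring-bearing compounds, with a number 12 percentage points higher from compound 1 to compound 4 (beyond the scatter), while the 1H-pyrazol-5-yl group remains ahead, as methoxy gives a number 18 percentage points lower from compound 2 to compound 4 (beyond the scatter). Among these four compounds, then, the response does not simply follow the size of the group, since the small methoxy group of compound 4 lies above two larger ring groups and below a third.

No measurement shown here explains why the response moves in these directions. On these data alone, what an amine, a carboxylic acid or a longer ether chain would give on this aromatic carbon remains open, as does whether a second chain-type group would behave like methoxy or whether compound 4 stands alone.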